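The source may report more compounds than this note shows. Statements on the series, on what has been measured and on what is new or still open speak of the compounds shown alone.

Compound 1 `Cc1ncnc2c1c(-c1ccsc1)cn2[C@@H]1O[C@H](CO)[C@@H](O)[C@H]1O` gives 5550 nM in a functional assay on K562 cells (Homo sapiens), read by MTT assay, with a stated time of 72 h; a lower number here means a stronger inhibitor, a higher number a weaker inhibitor. Compound 3 `C#Cc1cn([C@@H]2O[C@H](CO)[C@@H](O)[C@H]2O)c2ncnc(C)c12` gives 110 nM. For the measured compounds named here, the one change between them, ethynyl in place of thiophen-3-yl on an aromatic carbon, gives a 50-fold lower number from compound 1 to compound 3 (1.70 log units; beyond the scatter). Compound 2 `Cc1nc(N)c2c(-c3cccs3)cn([C@@H]3O[C@H](CO)[C@@H](O)[C@H]3O)c2n1` is the weakest of the three measured; in this assay compound 2 gives only a limit, > 20000 nM. Compound 2 stands at the limit of > 20000 nM in this assay, at which 1 of the 3 values shown sits. Compound 4 `Cc1nc(N)c2c(-c3ccoc3)cn([C@@H]3O[C@H](CO)[C@@H](O)[C@H]3O)c2n1` differs from compound 2 by furan-3-yl in place of thiophen-2-yl on an aromatic carbon. Going by the values given here, no measured step covers this exchange of one five-membered aromatic ring for another; the sole measured step concerns a different group. Compound 4 is therefore expected near 20000 nM, between 7000 nM and 60000 nM. The expected step is a number no higher from compound 2 to compound 4 (the limit leaves the size open), most likely again only a limit.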

Compound 4, half-maximal inhibitory concentration: > 20000 nM
Compound 4 ended at the assay's limit; the forecaster's own chance of this, stated with the estimate: 60%; the middle value lies on the limit itself.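

Compound 2 and compound 4 both end at a limit, so no step can be read between them: the limit of > 20000 nM in this assay, at which 2 of the 4 values shown sit. The compounds shown leave open how furan-3-yl and thiophen-2-yl compare on the shared core.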